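Shrinking the acyl group: from furan-2-yl to methyl

This account rests on a few compounds, and the source may have more. Where it says the series, first, only, none or still open, it means among the compounds named here.

The series shares a core in which an amide is varied on its carbonyl carbon. In a functional assay on NCI-H460 cells (Homo sapiens) for cytotoxicity (on this read-out higher numbers stand for weaker inhibition and lower numbers for stronger inhibition), compound 3 `COc1ccc(S(=O)(=O)N2CCc3cccc(NC(=O)c4ccco4)c32)cc1` gives 9.8 nM, the lowest number of the three; compound 2 `COc1ccc(S(=O)(=O)N2CCc3cccc(NC(=O)c4cccs4)c32)cc1` gives 49 nM and compound 1 `COc1ccc(S(=O)(=O)N2CCc3cccc(NC(=O)c4ccc([N+](=O)[O-])cc4)c32)cc1` gives 122 nM. The measured steps were a 2.5-fold lower number from compound 1 to compound 2 (0.40 log units; beyond the scatter), a 5.0-fold lower number from compound 2 to compound 3 (0.70 log units; beyond the scatter) and a 12-fold lower number from compound 1 to compound 3 (1.10 log units; beyond the scatter). Compound 4 `COc1ccc(S(=O)(=O)N2CCc3cccc(NC(C)=O)c32)cc1` differs from compound 3 by methyl in place of furan-2-yl on a carbonyl carbon. Every measured step swaps one ring for another on that carbonyl carbon, so none bears directly on removing the ring; they only show that this position shifts the number well beyond the scatter. A weaker result is therefore expected for compound 4, about a 6.1-fold higher number from compound 3 to compound 4 (0.79 log units; beyond the scatter), estimated at 60 nM within 15 nM to 300 nM.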

Compound 4, half-maximal inhibitory concentration: 75 nM
Estimate against measurement, compound 4: 1.3-fold (0.10 log units) below; low and high end bracket the measured number.
By their numbers in this assay, from the lowest: compound 3; then compounds 2, 4 and 1 (each within the scatter of the next, the first and the last beyond it).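

In this assay, a ring on the carbonyl carbon proves unnecessary for reaching the range of the two weaker amides: methyl stands level with thiophen-2-yl (a 1.5-fold higher number from compound 2 to compound 4 (0.18 log units; within the scatter)) and with 4-nitrophenyl (a 1.6-fold lower number from compound 1 to compound 4 (0.21 log units; within the scatter)). Only furan-2-yl stands apart (a 7.7-fold higher number from compound 3 to compound 4 (0.88 log units; beyond the scatter)), so among these four compounds the low number goes with that particular ring, not with the presence of a ring as such. No measured evidence explains this result.
On these data alone, it remains open whether a longer chain such as propyl, or an amine such as dimethylamino, on that carbonyl carbon would stay level with compound 4 or come closer to compound 3.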